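Swapping Phenyl for Thiazolyl and the Tolerated Concentration

The compounds below may be only part of what the source reports. "The series", "measured", "known", "first", "only" and "open" are said of these compounds alone.

Measured so far in an ADME assay on LLC-MK2 cells (Macaca mulatta) for cytotoxicity, read by spectrophotometry and crystal violet staining, with a stated time of 4 days; a lower number here means that less compound is tolerated, a higher number that more compound is tolerated:
Compound 1, `CC(C)n1ncc2c(C(=O)Nc3ccccc3F)cc(-c3ccccn3)nc21`, gives 100000 nM.
Compound 2, `CC(C)n1ncc2c(C(=O)Nc3ccccc3F)cc(-c3ccccc3)nc21`, gives > 200000 nM.

The value of compound 2 is a limit of the assay, not a number. It sits at the limit of > 200000 nM in this assay, at which 1 of the 2 values shown sits, so only a floor is known for it. Going by the values given here, the one measured step, an at least 2.0-fold higher number from compound 1 to compound 2 (0.30 log units; that floor lies within the scatter), is therefore itself a floor, and that floor lies within the usual scatter of repeated measurements, so the two compounds may in truth be close.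

Compound 3, `CC(C)n1ncc2c(C(=O)Nc3ccccc3F)cc(-c3cncs3)nc21`, is not yet measured. Its change from compound 2 is 1,3-thiazol-5-yl in place of phenyl on an aromatic carbon. This runs the opposite way to the measured step: a ring with hetero atoms and acceptors enters where compound 1 also carried such a ring. Compound 1 gave 100000 nM with a pyridin-2-yl there. A modest move back toward that level is expected, though possibly no further than the scatter, and a limit is again quite possible.

Compound 3 is expected at 150000 nM, with a range from 60000 nM to 400000 nM. This estimate means an expected step of an at least 1.3-fold lower number from compound 2 to compound 3 (0.12 log units; that floor lies within the scatter).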

Compound 3, half-maximal cytotoxic concentration: 100000 nM
Compound 3: the middle estimate sits 1.5-fold (0.18 log units) above what was measured; measured number inside the range.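

At this position on the shared core, the pyridin-2-yl ring and the 1,3-thiazol-5-yl ring, a five-membered aromatic ring with 2 hetero atoms, cannot be told apart in this assay: the comparison gives no change at the digits printed from compound 1 to compound 3 (within the scatter). The comparison with the carbon-only phenyl ring gives an at least 2.0-fold lower number from compound 2 to compound 3 (0.30 log units; that floor lies within the scatter), so the second ring with hetero atoms repeats the relation seen with the first, but still without a separation that clears the usual scatter. Compound 2 remains the only one of the three compounds whose value is a limit of the assay: the limit of > 200000 nM in this assay, at which 1 of the 3 values shown sits.

From the compounds shown here alone, it therefore stays unsettled whether the phenyl ring truly differs from these two rings with hetero atoms, since the true size of the gap is unknown and its printed floor does not exceed the scatter. The compounds shown also leave open what a non-aromatic group at this position would give, such as a morpholine ring or a simple amine, and what a carboxylic acid attached to the phenyl ring would do.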